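This account rests on a few compounds, and the source may have more. Where it says the series, first, only, none or still open, it means among the compounds named here.

Of the compounds shown here, three that share one core have so far been tested in a functional assay on cells for positive allosteric modulation of G-protein coupled receptor 68 (Homo sapiens), read by a luciferase reporter and cAMP accumulation, with a stated time of 30 min, at pH 6.8 and pH 8.3, in the presence of a further agent that is not named here; on this read-out lower numbers stand for lower potency and higher numbers for higher potency (the scale is a negative logarithm). Compound 1 `Nc1nc(NCc2ccccc2Cl)nc(-c2ccccc2CO)n1` gives 5.07. Compound 2 `Nc1nc(NCc2ccc(Cl)cc2)nc(-c2ccccc2CO)n1` gives 5.22. Compound 3 `Cc1ccccc1CNc1nc(N)nc(-c2ccccc2CO)n1` gives 4.7. Compound 2 holds the highest of these three numbers, but the step of a number 0.15 log units higher from compound 1 to compound 2 (within the scatter) lies within the scatter, so those two cannot be placed in order. The steps of a number 0.52 log units lower from compound 2 to compound 3 (beyond the scatter) and a number 0.37 log units lower from compound 1 to compound 3 (beyond the scatter) lie beyond the scatter, and both end at the compound that carries methyl rather than chloro.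

Compound 4 `CCOc1ccc(CNc2nc(N)nc(-c3ccccc3CO)n2)cc1` is not yet measured. It differs from compound 2 by ethoxy in place of chloro on an aromatic carbon. Within the data shown here, two measured steps bear on this. The exchange of chloro for methyl in a number 0.37 log units lower from compound 1 to compound 3 (beyond the scatter) lowered the number modestly, while moving chloro around the ring in a number 0.15 log units higher from compound 1 to compound 2 (within the scatter) changed little. Removing chloro therefore looks like it costs something, and an ethoxy group has not been tried on this core at all, so a small drop, around the edge of the scatter, is expected for compound 4 in this assay, as a number 0.22 log units lower from compound 2 to compound 4 (within the scatter). Compound 4 is thus estimated at 5, with a range from 4.5 to 5.5.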

Compound 4, negative logarithm of the antagonist equilibrium constant: 4.77
The estimate for compound 4 lay 0.23 log units above the measured number; the measured number falls inside the stated range.
By their numbers in this assay, from the lowest: compounds 3, 4, 1 and 2 (each within the scatter of the next, the first and the last beyond it).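

Among these compounds, until now, chloro was the only group seen at this place on the ring, para to a large group, so nothing showed whether the group there matters in this assay. The change to ethoxy brings a number 0.45 log units lower from compound 2 to compound 4 (beyond the scatter), so the number does respond to what sits at this place, although the step is modest and compound 4 keeps a measurable value with a group of three heavy atoms in place of a single chlorine. Nothing measured here explains the drop, and no reason for it can be given from these data.

The exchange also alters two things at once, since ethoxy brings both more heavy atoms and a hydrogen-bond acceptor, and the two compounds alone cannot tell these apart. A propyl chain, which keeps the length of ethoxy but has no oxygen, would help to separate them on the shared core, while an amine or a carboxylic acid at the same place would show how far the number moves with groups of quite another kind.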